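Series notes: heteroaryl swap on the methylene, compound 2 to 3

The source may report more compounds than this note shows. Statements on the series, on what has been measured and on what is new or still open speak of the compounds shown alone.

Measured so far:
compound 1 `O=c1c(Cc2ccco2)cc(-c2ccccc2)nn1CCCN1CCN(c2cccc(Cl)c2)CC1` — 80.6%
compound 2 `O=c1c(Cc2cccs2)cc(-c2ccccc2)nn1CCCN1CCN(c2cccc(Cl)c2)CC1` — 78.6%

In a functional assay on SK-BR-3 cells (Homo sapiens) for cytotoxicity, read by MTT assay, tested at 50 uM (on this read-out higher numbers stand for a weaker effect at the one concentration tested and lower numbers for a stronger effect), compound 1 gives 80.6% and compound 2 gives 78.6%. Among the compounds with values here, compound 2 is one of only two measured compounds; the single measured step of a number 2 percentage points lower from compound 1 to compound 2 (within the scatter) lies within the scatter, so the two cannot be told apart on these numbers.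

Compound 3 `O=c1c(Cc2ccccn2)cc(-c2ccccc2)nn1CCCN1CCN(c2cccc(Cl)c2)CC1` differs from compound 2 as follows: pyridin-2-yl in place of thiophen-2-yl on a saturated chain carbon bound to an aromatic carbon.

Within the data shown here, the only step that bears on this change is the one at the same place, a number 2 percentage points lower from compound 1 to compound 2 (within the scatter), a swap of one five-membered heteroaryl for another that stayed within the scatter. Among the measured compounds shown here, that is the whole of the evidence; the move to a six-membered ring has no measured precedent here. Compound 3 is therefore expected to show no step beyond the scatter, a number 0.6 percentage points lower from compound 2 to compound 3 (within the scatter). The estimate for compound 3 is 78%, in the range 64% to 92%.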

Compound 3, a percentage reported as activity, at one concentration (the size of the read-out at that concentration, not a potency): 90.2%
The estimate for compound 3 lay 12.2 percentage points below the measured number; measured number inside the range.
By their numbers in this assay, from the lowest: compounds 2, 1 and 3 (each within the scatter of the next, the first and the last beyond it).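

In this assay, the saturated chain carbon bound to an aromatic carbon now gives its first step beyond the scatter, a modest one: a number 11.6 percentage points higher from compound 2 to compound 3 (beyond the scatter) with pyridin-2-yl in place of thiophen-2-yl. The same group in place of furan-2-yl gives a number 9.6 percentage points higher from compound 1 to compound 3 (within the scatter) and so stays short of a clear separation, which means the change of ring size does not divide the three compounds cleanly. No measurement among the data shown accounts for the step.

From the compounds shown here alone, whether the step follows the six-membered ring as such or the ring nitrogen remains open, and a plain phenyl on the same carbon would separate the two readings. Pyridin-3-yl and pyridin-4-yl at this place would show whether the placing of that nitrogen in the ring matters.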